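The source may report more compounds than this note shows. Statements on the series, on what has been measured and on what is new or still open speak of the compounds shown alone.

Working notes on the oxadiazole sulfonamide series.

Compound 1 `Cc1ccc(-c2nnc(-c3cccc(S(N)(=O)=O)c3)o2)cc1` gives 571 nM in an assay on cells for inhibition of Amine oxidase [flavin-containing] B (Homo sapiens), read by fluorescence and spectrophotometry, using microsomes, with a stated time of 20 min; on this read-out lower numbers stand for stronger inhibition and higher numbers for weaker inhibition. Going by the values given here, compound 2 `NS(=O)(=O)c1cccc(-c2nnc(-c3ccc(Cl)cc3)o2)c1` gives 210 nM, and the single change chloro in place of methyl on an aromatic carbon produced a 2.7-fold lower number from compound 1 to compound 2 (0.43 log units; beyond the scatter). Compound 3 `Cc1ccc(-c2nnc(-c3ccccc3)o2)cc1S(N)(=O)=O` gives 767 nM; the difference between the core of compound 3 and the core of compound 1 is not broken down here. Compound 4 `NS(=O)(=O)c1cc(-c2nnc(-c3ccccc3)o2)ccc1Cl` is not yet measured and differs from compound 3 by chloro in place of methyl on an aromatic carbon. This is the same kind of change as in compound 2, but not the same: in compound 4 the place is ortho to a sulfamoyl group as well as para to a large group. The step from compound 3 to compound 4 is expected to be a 2.4-fold lower number from compound 3 to compound 4 (0.38 log units; beyond the scatter), resting on compound 2 because a 2.7-fold lower number from compound 1 to compound 2 (0.43 log units; beyond the scatter) was seen. Compound 4 is estimated at 320 nM, within 120 nM to 850 nM.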

Compound 4, half-maximal inhibitory concentration: 439 nM
For compound 4 the middle estimate is 1.4-fold (0.14 log units) below the measured one; low and high end bracket the measured number.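

In this assay, chloro in place of methyl on the core of compound 3 gives a 1.7-fold lower number from compound 3 to compound 4 (0.24 log units; within the scatter), a step that taken alone cannot be told apart from repeat measurements. Set beside the earlier step, the change carries across these two cores with no difference the data can resolve: the same change on two cores in this assay, a 2.7-fold lower number (0.43 log units; beyond the scatter) from compound 1 to compound 2 and a 1.7-fold lower number (0.24 log units; within the scatter) from compound 3 to compound 4, 1.6-fold (0.19 log units) apart, within the scatter of two such steps. This is agreement on two cores only; it does not establish that the step keeps its size on a third core, and it does not turn the step on the core of compound 3 into a clear one.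

The compounds shown leave open how fluoro, methoxy or trifluoromethyl would compare with chloro at these places. They also leave open whether an amine or a carboxylic acid could stand in for the sulfamoyl group.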